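Cytotoxicity of Three Compounds, With a Fourth Expected

The compounds below may be only part of what the source reports. "The series", "measured", "known", "first", "only" and "open" are said of these compounds alone.

The measured compounds, in an ADME assay on L929 cells (Mus musculus) for cytotoxicity, read by resazurin assay, with a stated time of 72 h; on this read-out lower numbers stand for stronger inhibition and higher numbers for weaker inhibition:
compound 1 `OB1OCc2ccc(-n3cc(Sc4ccc(Cl)c(Cl)c4)c4ccccc43)cc21` gives > 10 ug/mL, which is a limit of the assay and not a number.
compound 2 `OB1OCc2ccc(-n3cc(Sc4cccc(Cl)c4)c4ccccc43)cc21` gives > 10 ug/mL, again a limit.
compound 3 `O=C(c1ccccc1)c1ccn(-c2ccc3c(c2)B(O)OC3)c1` gives > 10 ug/mL, also a limit.

Compounds 1 and 2 share a core and differ by one change, (chloro in place of hydrogen on an aromatic carbon). The step that the two limits leave unreadable from compound 2 to compound 1 cannot be read, since both values are limits. The difference between the core of compound 3 and that of compound 2 is not broken down here.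

Compound 4 `O=C(c1ccn(-c2ccc3c(c2)B(O)OC3)c1)c1ccccc1Cl` is not yet measured. It differs from compound 3 by chloro in place of hydrogen on an aromatic carbon. Among the compounds with values here, this is the same kind of change as the one from compound 2 to compound 1, but not the same: there the chlorine enters ortho to a chloro group (1 heavy atom) and para to a large group, whereas in compound 4 it enters ortho to a large group.

What the three measurements share is the limit of > 10 ug/mL in this assay, at which 3 of the 3 values shown sit. None of the compounds shown gives a number in this assay, and the one measured example of this kind of change leaves its step unreadable. On that basis compound 4 is expected to sit at the same limit, so the step that the limit leaves unreadable from compound 3 to compound 4 is expected to be small or unreadable. The estimate for compound 4 in this assay is 15 ug/mL, with a range from 5 ug/mL to 40 ug/mL.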

Compound 4, half-maximal inhibitory concentration: > 10 ug/mL
Compound 4: only a limit was reported; the forecaster's own chance of this, stated with the estimate: 80%; the middle value is on the limit's open side.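

In this assay compound 4 gives > 10 ug/mL, which is a limit and not a number, so the step from compound 3 to compound 4 cannot be read. The same holds across the whole set: the limit of > 10 ug/mL in this assay, at which 4 of the 4 values shown sit.

The compounds shown leave open what the actual values are, and whether going from phenyl to 2-chlorophenyl changes cytotoxicity on these cells at all.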